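Amide aryl exchange on the shared core

The source may report more compounds than this note shows. Statements on the series, on what has been measured and on what is new or still open speak of the compounds shown alone.

Compound 2 `COc1cc(OC)cc(C(=O)Nc2cccc(-c3oc4cc(-c5ccc(F)cc5)ccc4c(=O)c3O)c2)c1` gives 6250 nM in a functional assay on HCC1937 cells (Homo sapiens) for antiproliferative activity, read by CCK-8 assay, with a stated time of 72 h; on this read-out lower numbers stand for stronger inhibition and higher numbers for weaker inhibition. Within the data shown here, compound 1 `Cc1cc(C(=O)Nc2cccc(-c3oc4cc(-c5ccc(F)cc5)ccc4c(=O)c3O)c2)ccc1F` gives 5420 nM in this assay, and the step of a 1.2-fold higher number from compound 1 to compound 2 (0.06 log units; within the scatter) shows that the two numbers sit within the scatter of each other, so compound 2 has no separate standing among the numbers so far. Compound 3 `N#Cc1ccc(C(=O)Nc2cccc(-c3oc4cc(-c5ccc(F)cc5)ccc4c(=O)c3O)c2)cc1` differs from compound 2 by 4-cyanophenyl in place of 3,5-dimethoxyphenyl on a carbonyl carbon. Among the measured compounds shown here, only the step from compound 1 to compound 2 bears on this aryl exchange, and it was within the scatter, so no step beyond the scatter is expected in this assay. Compound 3 is estimated at 5800 nM, between 2500 nM and 13000 nM, meaning an expected step of a 1.1-fold lower number from compound 2 to compound 3 (0.03 log units; within the scatter).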

Compound 3, half-maximal inhibitory concentration: 2990 nM
Compound 3: the middle estimate sits 1.9-fold (0.29 log units) above what was measured; the range from low to high includes it.
By their numbers in this assay, from the lowest: compounds 3, 1 and 2 (each within the scatter of the next, the first and the last beyond it).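

Unlike the earlier step, exchange at this carbonyl carbon now moves the number in this assay beyond the scatter: 4-cyanophenyl in place of 3,5-dimethoxyphenyl gives a 2.1-fold lower number from compound 2 to compound 3 (0.32 log units; beyond the scatter) and that step is modest. Among these compounds, in place of 4-fluoro-3-methylphenyl the same group gives a 1.8-fold lower number from compound 1 to compound 3 (0.26 log units; within the scatter) and so only one of the two exchanges clears the scatter. Nothing at hand explains the step.

Open, as far as these compounds go, is whether an unsubstituted phenyl, a saturated amine or a carboxylic acid-bearing aryl on this carbonyl carbon would shift the number further. Also open, from the compounds shown here alone, is whether the 4-cyanophenyl step holds on other cores.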